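The source may report more compounds than this note shows. Statements on the series, on what has been measured and on what is new or still open speak of the compounds shown alone.

Measured so far:
- compound 1 `CC[C@H](C)[C@H](N)CN(C(=O)[C@@H]1C[C@H]1c1ccc(F)cc1)c1ccc(-c2ccccc2)cc1` gives 600 nM in a functional assay for agonist activity at G protein-coupled receptor 88 (Homo sapiens), read by HTRF and cAMP accumulation; on this read-out lower numbers stand for an effect already at smaller amounts and higher numbers for an effect only at larger amounts of compound
- compound 2 `CC[C@H](C)[C@H](N)CN(C(=O)[C@@H]1C[C@H]1c1cccnc1)c1ccc(-c2ccccc2)cc1` gives 1500 nM in this assay

Among these two numbers, compound 2 stands highest; its nearest neighbour is compound 1, and the step of a 2.5-fold higher number from compound 1 to compound 2 (0.40 log units; beyond the scatter) lies beyond the scatter of repeated measurements. Compound 3 `CC[C@H](C)[C@H](N)CN(C(=O)[C@@H]1C[C@H]1c1ccoc1)c1ccc(-c2ccccc2)cc1` has not yet been measured. It differs from compound 2 in a single place: furan-3-yl in place of pyridin-3-yl on a saturated ring carbon. For the measured compounds named here, only one measured step bears on this change, namely a 2.5-fold higher number from compound 1 to compound 2 (0.40 log units; beyond the scatter), in which a pyridin-3-yl group took the place of a 4-fluorophenyl group on the same saturated ring carbon and the number rose modestly. Going by the values given here, a furan-3-yl group on that carbon has no measured counterpart, so the single known step tells only that the number has shifted modestly when this group was exchanged. Compound 3 is therefore expected to land near or a little below compound 2, at an estimated 900 nM with a range of 300 nM to 2700 nM in this assay. That estimate for compound 3 means an expected step of a 1.7-fold lower number from compound 2 to compound 3 (0.22 log units; within the scatter).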

Compound 3, half-maximal effective concentration: 580 nM
Beside the measured number, compound 3's estimate is 1.6-fold (0.19 log units) above it; measured number inside the range.
By their numbers in this assay, from the lowest: compounds 3 and 1 (each within the scatter of the next); then compound 2.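

In this assay, exchanging pyridin-3-yl for furan-3-yl on a saturated ring carbon of the three-membered ring gives a 2.6-fold lower number from compound 2 to compound 3 (0.41 log units; beyond the scatter), so this position responds to the choice between these two aromatic rings even though the counted hetero atoms, donors and acceptors are the same in both groups. Comparing furan-3-yl with 4-fluorophenyl on the same carbon gives a 1.0-fold lower number from compound 1 to compound 3 (0.01 log units; within the scatter), which means that these two groups cannot be told apart in this assay, and a five-membered aromatic ring can stand here without a loss on this read-out. Among the three groups shown, pyridin-3-yl is thus the one that stands apart, whereas the first step alone could not show whether the higher number went with leaving 4-fluorophenyl or with that particular ring.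

Nothing at hand explains the gap between pyridin-3-yl and furan-3-yl. Also open, as far as these compounds go, is whether thiophen-3-yl, or a saturated group such as cyclohexyl, on this carbon would give a number close to that of compound 3 or to that of compound 2.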